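Tetrazole to thiadiazole swap on the thioether of compound 1

The source may report more compounds than this note shows. Statements on the series, on what has been measured and on what is new or still open speak of the compounds shown alone.

Among the compounds with values here, compound 1 `Cn1nnnc1SCC(=O)N/N=c1/scc(-c2ccccc2)n1-c1ccccc1` is the only member of the series with a number: in a functional assay on C6 cells (Rattus norvegicus) for cytotoxicity, read by MTT assay, with a stated time of 24 h (a higher number here means a weaker inhibitor, a lower number a stronger inhibitor), compound 1 gives 67.7 ug/mL. Compound 2 `Cn1nnnc1SCC(=O)N/N=c1/scc(-c2ccc(Br)cc2)n1-c1ccccc1` in this assay stands at "not determined" (no result reported), so the two values give nothing to compare. Compound 3 `Cc1nnc(SCC(=O)N/N=c2/scc(-c3ccccc3)n2-c2ccccc2)s1` is not yet measured. Its difference from compound 1: 5-methyl-1,3,4-thiadiazol-2-yl in place of 1-methyl-1H-tetrazol-5-yl on a sulfur. Within the data shown here, no measured step of this kind exists, so the expectation for compound 3 in this assay is a step from compound 1 that stays within the scatter, a 1.1-fold lower number from compound 1 to compound 3 (0.05 log units; within the scatter). Compound 3 is thus expected at 60 ug/mL, with a range from 30 ug/mL to 130 ug/mL.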

Compound 3, half-maximal inhibitory concentration: > 200 ug/mL
Compound 3 was reported as a limit (the forecaster's own chance of this, stated with the estimate: 10%); middle value at least 3.3-fold (0.52 log units) away from the limit.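

In this assay the group on the sulfur proves not to be a neutral position: 5-methyl-1,3,4-thiadiazol-2-yl in place of 1-methyl-1H-tetrazol-5-yl gives an at least 2.9-fold higher number from compound 1 to compound 3 (0.47 log units; beyond the scatter). Both groups are five-membered aromatic rings, so even an exchange of one such ring for another moves the read-out here. Compound 3 carries a limit, not a number, so the step has a floor but no measured size: the limit of > 200 ug/mL in this assay, at which 1 of the 3 values shown sits.

Open, going by these compounds, is whether any other ring on this sulfur matches the 1-methyl-1H-tetrazol-5-yl group. Also open, on these data alone, is how an open chain ending in an amine or a carboxylic acid would read in this assay.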